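One Aryl Swap on a Shared Core

The source may hold more compounds than are shown below. What is called first, only, known or untested is meant among the compounds shown, and "the series" means these compounds.

Measured in a physicochemical assay for solubility, read by spectrophotometry, in phosphate buffer, with a stated time of 18 h, at pH 7.4; on this read-out lower numbers stand for lower solubility and higher numbers for higher solubility:
- compound 1 `Cc1cccc(-c2nc3c(c(C)nn3-c3ccccc3)c(-c3ccccc3O)c2C#N)c1`: 42000 nM
- compound 2 `Cc1nn(-c2ccccc2)c2nc(-c3ccc(C(C)C)cc3)c(C#N)c(-c3ccccc3O)c12`: 9800 nM

Among the compounds with values here, of the two numbers so far, the lower belongs to compound 2, at 9800 nM. The next structure, compound 3 `Cc1nn(-c2ccccc2)c2nc(-c3ccc4ccccc4c3)c(C#N)c(-c3ccccc3O)c12`, keeps the shared core and changes one group: naphthalen-2-yl in place of 4-isopropylphenyl on an aromatic carbon, next to the ring nitrogen and ortho to a cyano group (naphthalen-2-yl in place of 4-isopropylphenyl on an aromatic carbon).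

Within the data shown here, only one measured step bears on this change, because it altered the same place on the core: a 4.3-fold lower number from compound 1 to compound 2 (0.63 log units; beyond the scatter). That step was modest, and a single step cannot establish a trend. Among the measured compounds shown here, the data also hold no compound with a naphthalen-2-yl group, so the forecast remains loose. A small move toward a lower number in this assay is expected, possibly no larger than the scatter. The expected step is a 1.6-fold lower number from compound 2 to compound 3 (0.21 log units; within the scatter). For compound 3 the estimated value is 6000 nM, with an expected range from 2000 nM to 18000 nM.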

Compound 3, solubility: 1800 nM
Compound 3: the middle estimate sits 3.3-fold (0.52 log units) above what was measured; the measured number lies below the stated range.
By their numbers in this assay, from the lowest: compound 3; then compound 2; then compound 1.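

In this assay, this position on the shared core, on an aromatic carbon next to the ring nitrogen and ortho to a cyano group, has now given a second step beyond the scatter: a 5.4-fold lower number from compound 2 to compound 3 (0.74 log units; beyond the scatter). The change in counted features is slight: naphthalen-2-yl brings 10 heavy atoms against 9 for 4-isopropylphenyl and a second six-membered aromatic ring of carbon only, while neither group has hydrogen-bond donors, hydrogen-bond acceptors or a net charge, so a large difference in these counts is not needed for a clear move in the number. Across the three compounds the swaps at this one position span a wide range, a 23-fold lower number from compound 1 to compound 3 (1.37 log units; beyond the scatter), although nothing here explains why these groups give these numbers, as no supporting measurement bears on the result.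

As far as these compounds go, all three groups at this position are built from carbon and hydrogen alone, so it remains open whether a phenyl ring carrying an amine or a carboxylic acid would reverse the fall. From the compounds shown here alone, it is also open whether a change to the 2-hydroxyphenyl group elsewhere on the core would move the number as strongly.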